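Shifting the halogen on the sulfonyl aryl ring

The source may report more compounds than this note shows. Statements on the series, on what has been measured and on what is new or still open speak of the compounds shown alone.

Compound 3 `Nc1cc(S(=O)(=O)c2ccc(Cl)cc2)c([N+](=O)[O-])c2cccnc12` is the reference point here. In an assay for binding affinity to Neuropeptide Y receptor type 1 (Homo sapiens), read by radioligand binding (on this read-out lower numbers stand for stronger inhibition and higher numbers for weaker inhibition), compound 3 gives 1750 nM. Two companions stop at the assay limit rather than giving a number. Compound 1 `Nc1cc(NS(=O)(=O)c2ccccc2)c([N+](=O)[O-])c2cccnc12` reaches only the limit of > 10000 nM. Compound 2 `Cc1cc(S(=O)(=O)c2ccccc2)c([N+](=O)[O-])c2cccnc12` likewise reaches only the limit of > 10000 nM. For the measured compounds named here, compound 3 therefore stands as the single measured number in this set, while the other two readings are limits, a picture summed up by the limit of > 10000 nM in this assay, at which 2 of the 3 values shown sit.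

Compound 4 `Nc1cc(S(=O)(=O)c2ccccc2Br)c([N+](=O)[O-])c2cccnc12` is the compound still to be tested. It differs from compound 3 in one place: 2-bromophenyl in place of 4-chlorophenyl on a sulfonyl sulfur. Going by the values given here, no measured pair in the set shares this change, so the expectation rests on the change alone. A step of moderate size toward weaker binding is expected in this assay, though it may not clear the usual scatter. The expected step from compound 3 to compound 4 is a 2.3-fold higher number from compound 3 to compound 4 (0.36 log units; beyond the scatter). For compound 4 the estimated value is 4000 nM, with a range from 1200 nM to 15000 nM.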

Compound 4, inhibition constant: 234 nM
For compound 4 the middle estimate is 17-fold (1.23 log units) above the measured one; measured number below the stated range.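

In this assay, replacing 4-chlorophenyl with 2-bromophenyl on the sulfonyl sulfur gives a 7.5-fold lower number from compound 3 to compound 4 (0.87 log units; beyond the scatter), so binding at this receptor clearly responds to what is carried on this aryl ring. For the compounds shown here, this is the first step in the set that can be read as a number, and it shows that this position can improve binding rather than merely tolerate a change. However, the halogen and its location on the ring change together in this single step, so the two contributions cannot be separated, and readings that give no number still make up much of the set: the limit of > 10000 nM in this assay, at which 2 of the 4 values shown sit.

From the compounds shown here alone, it remains open whether the gain belongs to bromine itself or to the location named in 2-bromophenyl. Nor do the compounds shown reveal how a fluorine atom or a methoxy group in place of that bromine would read.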